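Carbamate chain extension and maximal response in the series

The compounds below may be only part of what the source reports. "The series", "measured", "known", "first", "only" and "open" are said of these compounds alone.

Two members of the series have been measured in a functional assay on CHO-K1 cells with Glucose-dependent insulinotropic receptor (Homo sapiens) as the target, read by a luciferase reporter, with a stated time of 5 h; on this read-out lower numbers stand for smaller maximal responses and higher numbers for larger maximal responses. Compound 1 `COC(=O)N1CCC(Oc2ncnc3c2CCN3c2ccc(S(C)(=O)=O)cc2F)CC1` carries the methoxy carbamate and gives 119% there, while compound 2 `CCOC(=O)N1CCC(Oc2ncnc3c2CCN3c2ccc(S(C)(=O)=O)cc2F)CC1` carries the ethoxy carbamate and gives 135%. Among the compounds with values here, the single step between them, a number 16 percentage points higher from compound 1 to compound 2 (beyond the scatter), is the only measured step in the set, so compound 2 stands at the top of the two numbers, with compound 1 as its nearest neighbour below it by that step.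

Compound 3 `CCCOC(=O)N1CCC(Oc2ncnc3c2CCN3c2ccc(S(C)(=O)=O)cc2F)CC1` is the next homologue and differs from compound 2 by methyl in place of hydrogen on a saturated chain carbon, two bonds along the chain from an oxygen next to a carbonyl group; cut one bond further out the same difference reads ethoxy to propoxy. Within the data shown here, the only measured step that bears on it is a number 16 percentage points higher from compound 1 to compound 2 (beyond the scatter), which also put a methyl onto the carbamate chain. Whether a second extension of that chain continues the rise cannot be judged from one step, so the expectation in this assay is a small rise or none beyond the scatter, with a wide range. Compound 3 is expected to give 140% in this assay, between 115% and 165%. That estimate corresponds to an expected step of a number 5 percentage points higher from compound 2 to compound 3 (within the scatter) in this assay.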

Compound 3, largest response reached (reported as percent of maximum), in percent of the reference or control that the assay uses: 111%
Estimate against measurement, compound 3: 29 percentage points above, outside the stated range (below it).
By their numbers in this assay, from the lowest: compounds 3 and 1 (each within the scatter of the next); then compound 2.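

Carbamate chain length at this position does not act in one direction in this assay: the first methyl raised the response, whereas the second gives a number 24 percentage points lower from compound 2 to compound 3 (beyond the scatter) and so reverses the gain, a turn that the earlier pair could not show. Taken across both added carbons, the change from the methoxy carbamate to the propoxy carbamate gives a number 8 percentage points lower from compound 1 to compound 3 (within the scatter) and leaves these two chains indistinguishable on this read-out, so among the three compounds only the ethoxy carbamate of compound 2 stands apart, with steps beyond the scatter to both neighbours. No measurement is available that would account for this turn at the ethoxy carbamate.

Open, going by these compounds, is whether a butoxy carbamate or a longer chain stays at the level of compound 3 or falls further, and whether a branched isopropoxy carbamate behaves like the ethoxy or the propoxy chain. Also open, on these data alone, is whether the same turn appears when a urea or an amide takes the place of the carbamate on the shared core, since all three compounds carry the carbamate and differ only in its chain.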